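Methylamino replacing piperidinyl on the quinoline core

This account rests on a few compounds, and the source may have more. Where it says the series, first, only, none or still open, it means among the compounds named here.

Compound 1 `CCCc1cc(NC2CC2)c2cc(NC(=O)/C=C/c3ccc(C(F)(F)F)cc3)ccc2n1` gives 40 nM in an assay on isolated protein for displacement of a labelled ligand from melanin-concentrating hormone receptor 1 (Homo sapiens); a lower number here means a stronger inhibitor, a higher number a weaker inhibitor. Compound 2 `CCCc1cc(N2CCCCC2)c2cc(NC(=O)/C=C/c3ccc(C(F)(F)F)cc3)ccc2n1` reaches only the limit of > 4000 nM in this assay, at which 1 of the 2 values shown sits, in this assay, so for compound 2 the value > 4000 nM is a limit of the assay and not a number. Among the measured compounds shown here, the single measured step, an at least 100-fold higher number from compound 1 to compound 2 (2.00 log units; beyond the scatter), shows that exchanging the cyclopropylamino group for piperidin-1-yl on the shared core costs binding heavily.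

Compound 3 `CCCc1cc(NC)c2cc(NC(=O)/C=C/c3ccc(C(F)(F)F)cc3)ccc2n1` differs from compound 2 by methylamino in place of piperidin-1-yl on an aromatic carbon. The methylamino group restores a hydrogen-bond donor at the same place that the cyclopropylamino group of compound 1 occupies, so the step from compound 1 to compound 2 is the one that bears on it, and a reversal of comparable size is expected. The expected step is an at least 66-fold lower number from compound 2 to compound 3 (1.82 log units; beyond the scatter), a large drop in this assay. Compound 3 is therefore estimated at 60 nM, with a range from 15 nM to 300 nM.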

Compound 3, half-maximal inhibitory concentration: 1.5 nM
For compound 3 the middle estimate is 40-fold (1.60 log units) above the measured one; measured number outside the range, below it.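

Cyclopropylamino is not the best of the small amino groups at this position: methylamino gives a 27-fold lower number from compound 1 to compound 3 (1.43 log units; beyond the scatter), so the substituent on the nitrogen still tunes binding strongly in this assay when that nitrogen keeps its hydrogen. Against piperidin-1-yl the same group gives an at least 2600-fold lower number from compound 2 to compound 3 (3.42 log units; beyond the scatter), which widens the gap that the first pair of compounds had opened. For compound 2 the value is a limit of the assay and not a number: the limit of > 4000 nM in this assay, at which 1 of the 3 values shown sits.

The compounds shown do not separate the loss of the hydrogen-bond donor from the presence of the six-membered ring in piperidin-1-yl, a question that dimethylamino would bear on. On these data alone, whether ethylamino or the unsubstituted amino group would match compound 3 also stays open.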